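Trimming the alkene terminus of a bisguanidine polyamine analogue

A few compounds are considered here, and "the series" means these few. Any claim that something is new, unique, unknown or untested is made for them only; others in the source may bear on it.

Among the compounds with values here, compound 3 `CC(C)=CCNC(=N)NCCCCCCCCNCCCCCCCCNC(=N)N` gives 3 nM in an assay on isolated protein for inhibition of polyamine oxidase 1 (Zea mays), read by spectrophotometry, using a Dixon plot, at pH 6.5 (a lower number here means a stronger inhibitor, a higher number a weaker inhibitor), the lowest of the three numbers measured so far. Its nearest neighbour is compound 1 `CC(C)=CCNC(=N)NCCCCCN`, which in this assay gives 10 nM; the furthest is compound 2 `N=C(NCCCCCN)NCC1CC1`, which in this assay gives 2580 nM. Compound 4 `C/C=C/CNC(=N)NCCCCCCCCNCCCCCCCCNC(=N)N` has not yet been measured. It differs from compound 3 in one place: prop-1-en-1-yl in place of 2-methylprop-1-en-1-yl on a saturated chain carbon bound to an amine nitrogen. Within the data shown here, only one measured step touches this position, the move a 260-fold higher number from compound 1 to compound 2 (2.41 log units; beyond the scatter), in which a cyclopropyl took the place of the whole 2-methylprop-1-en-1-yl group. The change to compound 4 keeps the double bond and removes only a single methyl, so a much smaller effect is expected than that step showed. Among the measured compounds shown here, no measured pair shows exactly this trimming, so the direction is a guess; a modest weakening is expected for compound 4 because the step of a 260-fold higher number from compound 1 to compound 2 (2.41 log units; beyond the scatter) shows that cutting back this group went with a weaker number, giving an expected 2.7-fold higher number from compound 3 to compound 4 (0.43 log units; beyond the scatter). Compound 4 is therefore estimated at 8 nM in this assay, with an expected range from 2 nM to 40 nM.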

Compound 4, inhibition constant: 1.1 nM
Compound 4: middle estimate off by 7.3-fold (0.86 log units), on the high side, outside the stated range (below it).
By their numbers in this assay, from the lowest: compound 4; then compound 3; then compound 1; then compound 2.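

Taking a single methyl off the alkene terminus costs nothing in this assay: the change from 3-methylbut-2-en-1-yl to but-2-en-1-yl gives a step in the opposite direction to the one expected (a 2.7-fold lower number from compound 3 to compound 4 (0.44 log units; beyond the scatter)), so the full 3-methylbut-2-en-1-yl group is not needed for a low number in this long-chain parent. The large loss in the earlier step (a 260-fold higher number from compound 1 to compound 2 (2.41 log units; beyond the scatter)) therefore cannot be read as a general penalty for cutting back this group, since that step swapped the alkenyl group for a cyclopropyl on a different parent and the two steps now point in opposite directions. Nothing available here explains why trimming the group lowers the number in this parent.

The compounds shown leave open whether the same methyl removal would also lower the number on the shorter parent, compound 1, or whether the double bond itself matters at this place. A saturated butyl or a shorter allyl group on the same nitrogen would address the second question, and the cis form of but-2-en-1-yl would show whether the alkene geometry counts.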